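The source may report more compounds than this note shows. Statements on the series, on what has been measured and on what is new or still open speak of the compounds shown alone.

Three measured compounds frame the question. In a functional assay on SK-BR-3 cells (Homo sapiens) for cytotoxicity, read by sulforhodamine B assay, with a stated time of 48 h (on this read-out higher numbers stand for weaker inhibition and lower numbers for stronger inhibition), compound 1 `CO[C@@H]1CC=C2NN(c3ccc(C)cc3)C(=O)CC[C@]2(c2ccccc2)O1` gives 2700 nM. For the measured compounds named here, compound 2 `CO[C@@H]1CC=C2NN(c3c[nH]c4ccccc34)C(=O)CC[C@]2(c2ccccc2)O1` gives 1200 nM in this assay, and the one measured step between compounds that differ in a single place is a 2.3-fold lower number from compound 1 to compound 2 (0.35 log units; beyond the scatter), a modest shift towards stronger inhibition. Compound 3 `CO[C@@H]1CC=C2N(c3ccc(C)cc3)C(=O)C[C@]2(c2ccccc2)O1`, built on a different core, gives 1100 nM in this assay, the lowest of the three numbers; its gap to compound 2 is within the scatter, while its gap to compound 1 is beyond it, so compound 3 can be set apart from compound 1 but not from compound 2.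

Compound 4 `CO[C@@H]1CC=C2N(c3cc(Cl)cc(Cl)c3)C(=O)C[C@]2(c2ccccc2)O1` differs from compound 3 in one place: 3,5-dichlorophenyl in place of 4-methylphenyl on an amide-type nitrogen in a ring. Going by the values given here, no measured pair exchanges 4-methylphenyl for 3,5-dichlorophenyl, on this core or any other. Among the compounds with values here, the only step that changes the group on the amide-type nitrogen in a ring is a 2.3-fold lower number from compound 1 to compound 2 (0.35 log units; beyond the scatter), and that step puts an indole ring in place of the aryl group, on the core of compound 1 rather than that of compound 3. Since the data on aryl swaps are this thin, the step of a 1.2-fold lower number from compound 3 to compound 4 (0.09 log units; within the scatter) is expected to be small and may lie within the scatter in either direction. For compound 4 in this assay the estimate is 900 nM, within a range of 300 nM to 2700 nM.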

Compound 4, half-maximal inhibitory concentration: 6540 nM
Beside the measured number, compound 4's estimate is 7.3-fold (0.86 log units) below it; the measured number lies above the stated range.
By their numbers in this assay, from the lowest: compounds 3 and 2 (each within the scatter of the next); then compound 1; then compound 4.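

In this assay the step of a 5.9-fold higher number from compound 3 to compound 4 (0.77 log units; beyond the scatter) shows that the aryl group on the amide-type nitrogen in a ring of the five-membered non-aromatic ring is not a silent place on this core: with 3,5-dichlorophenyl in place of 4-methylphenyl, the number moves beyond the scatter towards weaker inhibition. For the compounds shown here, until now the only change of this group was on the core of compound 1, where 1H-indol-3-yl in place of 4-methylphenyl went the other way in the step of a 2.3-fold lower number from compound 1 to compound 2 (0.35 log units; beyond the scatter), so the two swaps together show that the direction of change depends on the group, the core or both, and no single trend covers them. Nothing available bears on why this swap raises the number.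

Going by these compounds alone, the single pair cannot separate the effect of adding the two chlorine atoms from that of removing the methyl group, and a phenyl ring carrying one chlorine, a methoxy group or an amine would help to tell these apart. As far as these compounds go, it also remains open whether 3,5-dichlorophenyl would shift the number in the same way on the core of compound 1.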